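The compounds below may be only part of what the source reports. "The series", "measured", "known", "first", "only" and "open" are said of these compounds alone.

Measured in a functional assay on MDA-MB-231 cells (Homo sapiens) for antiproliferative activity, read by MTT assay, with a stated time of 72 h; a lower number here means a stronger inhibitor, a higher number a weaker inhibitor:
- compound 1 `O=C(CCc1cccc2c1B(O)OC2)Nc1ccc(F)cc1`: 440 nM
- compound 2 `O=C(CCc1cccc2c1B(O)OC2)Nc1ccc(Br)cc1`: 5300 nM
- compound 3 `CC(C)(C)OC(=O)Nc1ccc(NC(=O)CCc2cccc3c2B(O)OC3)cc1`: 29000 nM

All three share one core and differ only in the group on the outer aromatic ring. Of the three, compound 3 has the highest number, 29000 nM, which makes it the weakest inhibitor here.

The next molecule, compound 4 `CC(C)(C)OC(=O)NCc1ccc(NC(=O)CCc2cccc3c2B(O)OC3)cc1`, makes one small change to compound 3: ((tert-butoxycarbonyl)amino)methyl in place of (tert-butoxycarbonyl)amino on an aromatic carbon.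

The measured steps touch the same place on the ring. The change of group gave a 12-fold higher number from compound 1 to compound 2 (1.08 log units; beyond the scatter), then a 66-fold higher number from compound 1 to compound 3 (1.82 log units; beyond the scatter) and a 5.5-fold higher number from compound 2 to compound 3 (0.74 log units; beyond the scatter). All three lie beyond the scatter, and all three went upward, but each one swapped a whole group for a different one. The change to compound 4 keeps the tert-butoxycarbonyl and amino parts and only adds the methyl link, so none of these steps measures it directly. Even the smallest of them, a 5.5-fold higher number from compound 2 to compound 3 (0.74 log units; beyond the scatter), is a far bigger edit, so a much smaller effect seems likely.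

No step beyond the scatter is expected in this assay, and the expected change is a 1.1-fold higher number from compound 3 to compound 4 (0.04 log units; within the scatter). For compound 4 the estimate is 32000 nM, with an expected range of 10000 nM to 90000 nM.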

Compound 4, half-maximal inhibitory concentration: 1300 nM
Compound 4: the middle estimate sits 25-fold (1.39 log units) above what was measured; the measured number lies below the stated range.
By their numbers in this assay, from the lowest: compound 1; then compound 4; then compound 2; then compound 3.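

In this assay the methyl link between the ring and the (tert-butoxycarbonyl)amino part gives a 22-fold lower number from compound 3 to compound 4 (1.35 log units; beyond the scatter) and counts as a large step, so this position on the outer ring can respond strongly to a very small edit, not only to the swap of one whole group for another. The first three compounds could be read as a rising series from fluoro through bromo to (tert-butoxycarbonyl)amino, but the new compound breaks that reading: it shows a 4.1-fold lower number from compound 2 to compound 4 (0.61 log units; beyond the scatter) and so beats the bromo compound despite carrying the larger group, while a 3.0-fold higher number from compound 1 to compound 4 (0.47 log units; beyond the scatter) still leaves the fluoro compound ahead. Nothing measured here explains why the link has this effect.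

From the compounds shown here alone, it remains open whether the drop depends on the methyl link alone or also on the tert-butoxycarbonyl part, a question that a free aminomethyl group at the same place would help to settle. A longer chain, such as an ethyl link to the same carbamate, would show whether the number keeps falling as the link grows or whether the methyl link is a special case.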